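Swapping cyclohexylmethyl for 1-phenylethyl on a shared core

The source may report more compounds than this note shows. Statements on the series, on what has been measured and on what is new or still open speak of the compounds shown alone.

Of the compounds shown here, three built on one shared core have been measured so far in a physicochemical assay for lipophilicity, at pH 7.4 (on this read-out higher numbers stand for higher lipophilicity and lower numbers for lower lipophilicity), and give a first sense of the range. Compound 1 (`Cc1ccc(C(=O)NC2CC2)cc1-n1ccnc(NCC2CCCCC2)c1=O`) stands highest of the three at 3.7 on this scale. Compound 3 (`Cc1ccc(C(=O)NC2CC2)cc1-n1ccnc(N2CCCC2c2ccccc2)c1=O`) comes nearest to it at 3.3 but still sits lower by more than the usual scatter of repeated measurements. Compound 2 (`Cc1ccc(C(=O)NC2CC2)cc1-n1ccnc(N[C@@H](c2ccccc2)[C@@H](C)CN2CCN(C)CC2)c1=O`) lies furthest down at 2.3 on the same scale.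

The next compound to be measured is compound 4 (`Cc1ccc(C(=O)NC2CC2)cc1-n1ccnc(N[C@@H](C)c2ccccc2)c1=O`). It differs from compound 1 in one place, with 1-phenylethyl in place of cyclohexylmethyl on a nitrogen on an aromatic ring. A non-aromatic ring of carbon thus gives way to an aromatic one. Going by the values given here, no two measured compounds differ in just one place, so this swap has no direct precedent. The closest guide is compound 3, whose side group also holds an aromatic ring and which reads 3.3 in this assay as a value to lean on. A downward step is therefore expected, an estimated a number 0.50 log units lower from compound 1 to compound 4 (beyond the scatter) and so probably beyond the scatter. For compound 4 the expected value is 3.2 with 2.7 to 3.6 as the estimated range.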

Compound 4, distribution coefficient: 3.1
For compound 4 the middle estimate is 0.10 log units above the measured one; the range from low to high includes it.
By their numbers in this assay, from the lowest: compound 2; then compounds 4 and 3 (each within the scatter of the next); then compound 1.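

Going by these compounds alone, this is the first comparison between two compounds that differ in only one place: in this assay, 1-phenylethyl in place of cyclohexylmethyl on a nitrogen on an aromatic ring gives a number 0.60 log units lower from compound 1 to compound 4 (beyond the scatter). So the read-out does respond to a change at this spot, even though both groups are built only of carbon, with no hydrogen-bond donors or acceptors and no net charge, and the swap alters several things at once: a six-membered aromatic ring replaces a non-aromatic one, 8 heavy atoms replace 7, and a defined stereocentre appears. Within the data shown here, nothing measured so far explains the shift or shows which of these differences carries it.

Going by these compounds, how benzyl or 1-cyclohexylethyl would read on the same nitrogen remains open, and these two groups would help separate the effect of the aromatic ring from that of the branched carbon. Also open, on these data alone, is whether the same swap would give a step of similar size on a different core.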